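The compounds below may be only part of what the source reports. "The series", "measured", "known", "first", "only" and "open" are said of these compounds alone.

Working notes on the series. Compound 1 `C#CCN(CCCCOc1ccc2ccc(=O)oc2c1)Cc1cccc(OC)c1` and compound 2 `C#CCN(CCCOc1ccc2ccc(=O)oc2c1)Cc1ccc(C)cc1` share the coumarin-bearing core with a propargyl amine. Within the data shown here, in an assay on isolated protein for inhibition of Amine oxidase [flavin-containing] B (Homo sapiens), read by fluorescence and Amplex Red, with stated times of 15 min and 20 min (a lower number here means a stronger inhibitor, a higher number a weaker inhibitor), compound 1 gives 2340 nM, the lowest of the two numbers measured so far. In this assay compound 2 gives 7380 nM, a higher number than compound 1, and the gap between the two lies beyond the usual scatter. Among the measured compounds shown here, compound 2 differs from compound 1 in more than one place, so no single step can be drawn from the pair.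

Compound 3 `C#CCN(CCCCOc1ccc2ccc(=O)oc2c1)Cc1ccc(F)c(F)c1` is not yet measured. It differs from compound 1 in one place: 3,4-difluorophenyl in place of 3-methoxyphenyl on a saturated chain carbon bound to an amine nitrogen. For the measured compounds named here, no measured step of this kind exists, so the direction is open. The step from compound 1 to compound 3 is expected to be small, a 1.6-fold lower number from compound 1 to compound 3 (0.19 log units; within the scatter), and may fall within the scatter. In this assay compound 3 is estimated at 1500 nM, with a range from 400 nM to 6000 nM.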

Compound 3, half-maximal inhibitory concentration: 2370 nM
Beside the measured number, compound 3's estimate is 1.6-fold (0.20 log units) below it; low and high end bracket the measured number.
By their numbers in this assay, from the lowest: compounds 1 and 3 (each within the scatter of the next); then compound 2.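

In this assay, among these compounds, 3,4-difluorophenyl in place of 3-methoxyphenyl on a saturated chain carbon bound to an amine nitrogen gives a 1.0-fold higher number from compound 1 to compound 3 (0.01 log units; within the scatter), the first single-place step. At this position, the two groups cannot be told apart in this read-out, even though the exchange removes the hydrogen-bond acceptor counted for 3-methoxyphenyl and brings in fluorine. Nothing in the available evidence bears on why the two groups read alike.

The compounds shown leave open whether a plain phenyl or a pyridyl group at this place would read apart from these two. Among the compounds shown here, the effect of a longer chain to the coumarin oxygen also stays open; compound 2 differs from compound 1 in more than one place and gives no single step on chain length.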